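The source may report more compounds than this note shows. Statements on the series, on what has been measured and on what is new or still open speak of the compounds shown alone.

Measured compounds:
compound 1 `CC[C@H](C)[C@@H]1C(=O)N[C@H](C2Cc3ccccc3C2)C(=O)N1[C@@H](C(=O)N(C)C)c1ccc(C)[n+]([O-])c1` gives 1 mL.min-1.g-1
compound 2 `CC[C@H](C)[C@@H]1C(=O)N[C@H](C2Cc3ccccc3C2)C(=O)N1[C@@H](C(=O)N1CCOCC1)c1ccc(C)nc1` gives 6 mL.min-1.g-1
compound 3 `CC[C@H](C)[C@@H]1C(=O)N[C@H](C2Cc3ccccc3C2)C(=O)N1[C@@H](C(=O)NC)c1cc(C)cnc1C` gives 5 mL.min-1.g-1

All three share one core and were tested in an in vitro ADME assay on microsomes from liver (Macaca fascicularis) for metabolic stability; on this read-out lower numbers stand for slow clearance and higher numbers for fast clearance. On those numbers compound 1 stands lowest of the three. Its nearest neighbour is compound 3, whose value lies beyond the scatter above it, and the furthest is compound 2, also beyond the scatter above it.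

Compound 4 `CC[C@H](C)[C@@H]1C(=O)N[C@H](C2Cc3ccccc3C2)C(=O)N1[C@@H](C(=O)N(C)C)c1cnc(C)cc1C` has not been measured in this assay. It differs from compound 1 in one place: a group of 8 heavy atoms (7 carbon, 1 nitrogen; one six-membered aromatic ring with 1 hetero atom) in place of a group of 8 heavy atoms (6 carbon, 1 nitrogen, 1 oxygen; one six-membered aromatic ring with 1 hetero atom), on a saturated chain carbon bound to an amide-type nitrogen in a ring and a carbonyl carbon.

Among the compounds with values here, no step between two measured compounds isolates this change, so the expectation rests on the spread of the measured values. Within the data shown here, a ring group of the same kind as the one that enters in compound 4 is carried by compound 3, which gives 5 mL.min-1.g-1. The oxygen-bearing ring group of compound 1 is likewise absent from compound 2, which gives 6 mL.min-1.g-1. The step from compound 1 to compound 4 is therefore expected to run upward and beyond the scatter, about a 4.0-fold higher number from compound 1 to compound 4 (0.60 log units; beyond the scatter). Compound 4 is estimated at 4 mL.min-1.g-1, with a likely range from 2 mL.min-1.g-1 to 9 mL.min-1.g-1.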

Compound 4, intrinsic clearance in microsomes: 32 mL.min-1.g-1
Beside the measured number, compound 4's estimate is 8.0-fold (0.90 log units) below it, and the stated range ends below it.
By their numbers in this assay, from the lowest: compound 1; then compounds 3 and 2 (each within the scatter of the next); then compound 4.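

In this assay, within the data shown here, putting 4,6-dimethylpyridin-3-yl in place of the oxygen-bearing ring group, on a saturated chain carbon bound to an amide-type nitrogen in a ring and a carbonyl carbon, brings a 32-fold higher number from compound 1 to compound 4 (1.51 log units; beyond the scatter) and gives the first clean reading of a change at this place. The read-out thus responds strongly to the ring group here, although both groups count the same heavy atoms, no hydrogen-bond donors and one hydrogen-bond acceptor. Nothing available explains the size of this step.

The two ring groups differ in more than the oxygen, so the compounds shown do not tell how much of the step belongs to the oxygen and how much to the methyl groups. Going by these compounds, how an unsubstituted phenyl ring or a methoxy-bearing pyridine ring would read at this carbon also remains open.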